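Trimming the sulfur-linked side chain from compound 3 to compound 4

This account rests on a few compounds, and the source may have more. Where it says the series, first, only, none or still open, it means among the compounds named here.

Three measured compounds share one core and differ only in the group on the sulfur-linked chain. Compound 1 `Cc1ccc(CSc2nc3nc(C)cc(Nc4cc(-c5ccccc5)[nH]n4)n3n2)cc1` gives 7310 nM in a functional assay on PC-9 cells (Homo sapiens) for inhibition, read by MTT assay, with a stated time of 72 h; a lower number here means a stronger inhibitor, a higher number a weaker inhibitor. Compound 2 `Cc1cc(Nc2cc(-c3ccccc3)[nH]n2)n2nc(SCc3csc4ccccc34)nc2n1` gives 4420 nM, and compound 3 `Cc1cc(Nc2cc(-c3ccccc3)[nH]n2)n2nc(SCCc3ccccc3)nc2n1` gives 4930 nM. The steps of a 1.7-fold lower number from compound 1 to compound 2 (0.22 log units; within the scatter), a 1.5-fold lower number from compound 1 to compound 3 (0.17 log units; within the scatter) and a 1.1-fold higher number from compound 2 to compound 3 (0.05 log units; within the scatter) are all within the scatter, so compound 3 sits close to both partners, nearest to compound 2 and furthest from compound 1, with neither gap meaningful. Compound 4 `CCCSc1nc2nc(C)cc(Nc3cc(-c4ccccc4)[nH]n3)n2n1` is not yet measured. It differs from compound 3 in one place: methyl in place of phenyl on a saturated chain carbon, two bonds along the chain from a sulfur. Among the compounds with values here, every measured step exchanged one ring-bearing group for another on the chain carbon bound to the sulfur; none removed the ring altogether, so no measured step bears directly on this change. Those steps do show that varying the chain-end group moved the numbers little. The step expected in this assay is therefore a 1.3-fold higher number from compound 3 to compound 4 (0.12 log units; within the scatter), carrying wide uncertainty. Compound 4 is estimated at 6500 nM, with a range from 2000 nM to 22000 nM.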

Compound 4, half-maximal inhibitory concentration: > 50000 nM
Compound 4 ended at the assay's limit; the forecaster's own chance of this, stated with the estimate: 10%; at least 7.6-fold (0.88 log units) between middle value and limit.
By their numbers in this assay, from the lowest: compounds 2, 3 and 1 (each within the scatter of the next). At a limit, above all of these: compound 4.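

In this assay compound 4 gives > 50000 nM, which is a limit of the assay and not a number: the limit of > 50000 nM in this assay, at which 1 of the 4 values shown sits.

Removing the ring from the chain end does what exchanging one ring-bearing group for another never did, moving the result beyond the scatter in all three comparisons: an at least 10-fold higher number from compound 3 to compound 4 (1.00 log units; beyond the scatter), an at least 11-fold higher number from compound 2 to compound 4 (1.05 log units; beyond the scatter) and an at least 6.8-fold higher number from compound 1 to compound 4 (0.83 log units; beyond the scatter). So this position tolerated every ring-bearing group shown, yet the propylsulfanyl chain of compound 4 is far weaker than any of them.

On these data alone, what remains open is whether the ring itself counts or only the size of the chain end, which a longer chain such as hexyl or a saturated ring such as cyclohexyl could separate. The limit also leaves the full size of these steps unknown.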